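Notes on removing the core methyl of compound 1

The source may hold more compounds than are shown below. What is called first, only, known or untested is meant among the compounds shown, and "the series" means these compounds.

Measured so far in a functional assay on Bel7402/5-FU cells (Homo sapiens) for antiproliferative activity, read by MTT assay, with a stated time of 72 h; on this read-out higher numbers stand for weaker inhibition and lower numbers for stronger inhibition:
compound 1, `COc1cccc(CNCc2c(C(=O)O)n(Cc3ccc(C)cc3)c3cc(C)ccc23)c1`, gives 7310 nM.
compound 3, `COc1ccc(Cn2c(C(=O)O)c(CNCc3cccc(O)c3)c3ccc(C(C)C)cc32)cc1`, gives 15200 nM.
compound 2, `COc1cccc(CNCc2c(C(=O)O)n(Cc3ccc(O)cc3)c3cc(C(C)C)ccc23)c1`, reaches only a limit of the assay, > 50000 nM.

Of the two numbers recorded in this assay, compound 1 stands lowest; the nearest is compound 3, whose number is higher by a gap beyond the usual scatter. The value for compound 2 is a limit and not a number (the limit of > 50000 nM in this assay, at which 1 of the 3 values shown sits), so it is set aside for comparison.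

The unmeasured compound 4, `COc1cccc(CNCc2c(C(=O)O)n(Cc3ccc(C)cc3)c3ccccc23)c1`, keeps the whole substitution pattern of compound 1 apart from one change on the shared core: hydrogen in place of methyl on an aromatic carbon. Among the measured compounds shown here, no measured pair in the set differs in that single place, so no step can be read directly from the data.

The change removes one heavy atom and no donor or acceptor. On that basis the expected step in this assay from compound 1 to compound 4 is small, at most a modest rise in the number and possibly none beyond the scatter; the estimated step is a 1.3-fold higher number from compound 1 to compound 4 (0.11 log units; within the scatter). Compound 4 is expected to give about 9500 nM, within a range of 4000 nM to 25000 nM.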

Compound 4, half-maximal inhibitory concentration: 9330 nM
Estimate against measurement, compound 4: 1.0-fold (0.01 log units) above; the measured number falls inside the stated range.
By their numbers in this assay, from the lowest: compounds 1, 4 and 3 (each within the scatter of the next, the first and the last beyond it). At a limit, above all of these: compound 2.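

In this assay, hydrogen in place of methyl on this aromatic carbon of the shared core, meta to a fused ring and para to a fused ring, gives a 1.3-fold higher number from compound 1 to compound 4 (0.11 log units; within the scatter). Among the compounds shown here, this is the first pair that differs in one place, so the methyl can now be judged on its own, whereas compound 2 and compound 3 each differ from compound 1 in more than one place and could not show this; in this one pair, with the p-methylbenzyl and 3-methoxybenzylamine parts kept as they are, the methyl at this position is dispensable for a number of this size. Nothing in the data shown gives a reason for the size of this step.

The compounds shown leave open whether a chlorine, an amine or a longer chain such as propyl on this aromatic carbon would stay within the scatter of compound 1. They also leave open whether hydrogen in place of methyl here would give a step of the same size with other groups at the remaining places on the shared core.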